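The compounds below may be only part of what the source reports. "The series", "measured", "known", "first", "only" and "open" are said of these compounds alone.

Measured compounds:
- Compound 1 `COc1cc(-c2nnc(S)n2-c2ccc(N(C)C)cc2)cc(OC)c1OC`; in a functional assay on HepG2 cells (Homo sapiens) for inhibition, read by MTT assay, with a stated time of 48 h (a lower number here means a stronger inhibitor, a higher number a weaker inhibitor), compound 1 gives only a limit, > 60000 nM.
- Compound 2 `COc1cc(-c2nnc(SCc3ccc(F)cc3)n2-c2ccc(N(C)C)cc2)cc(OC)c1OC`; in this assay compound 2 gives 26400 nM.

Compound 2 holds the only number shown; the other value is a limit (the limit of > 60000 nM in this assay, at which 1 of the 2 values shown sits). Within the data shown here, the one measured step, an at least 2.2-fold lower number from compound 1 to compound 2 (0.35 log units; beyond the scatter), is the sole guide. Compound 3 `CCOC(=O)CSc1nnc(-c2cc(OC)c(OC)c(OC)c2)n1-c1ccc(N(C)C)cc1` differs from compound 2 by ethoxycarbonyl in place of 4-fluorophenyl on a saturated chain carbon bound to a sulfur. Among the measured compounds shown here, no measured step tests that swap. Since the only gain seen came with the 4-fluorobenzyl, its removal is expected to cost some potency, a step of a 1.6-fold higher number from compound 2 to compound 3 (0.20 log units; within the scatter). Compound 3 is therefore estimated at 42000 nM, between 15000 nM and 120000 nM.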

Compound 3, half-maximal inhibitory concentration: > 60000 nM
Compound 3: a limit, no number; the forecaster's own chance of this, stated with the estimate: 35%; middle value at least 1.4-fold (0.15 log units) away from the limit.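

At this place, on a saturated chain carbon bound to a sulfur, the 4-fluorophenyl cannot be exchanged for ethoxycarbonyl without loss: the change gives an at least 2.2-fold higher number from compound 2 to compound 3 (0.35 log units; beyond the scatter). Not every group on the sulfur therefore yields a measurable number, since compound 3 gives only a limit, > 60000 nM. The step from compound 1 to compound 3 cannot be read, and limits now prevail in this assay: the limit of > 60000 nM in this assay, at which 2 of the 3 values shown sit.

Whether the fluorine itself contributes remains open, as plain benzyl is not among the compounds shown. Also open, on these data alone, is how an amine, a carboxylic acid or a longer chain on the sulfur would read.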